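Bromo to iodo on the phenyl of compound 2

The compounds below may be only part of what the source reports. "The series", "measured", "known", "first", "only" and "open" are said of these compounds alone.

Measured so far:
compound 1 `CC(C)c1ccc(-n2nc(-c3ccc(C(F)(F)F)cc3O)nc2-c2ccccc2O)cc1` — 108%
compound 2 `Oc1cc(C(F)(F)F)ccc1-c1nc(-c2ccccc2O)n(-c2ccc(Br)cc2)n1` — 100%

In a functional assay on PC-12 cells (Rattus norvegicus) for cytotoxicity, read by MTT assay, with stated times of 2 h and 24 h, tested at 10 uM (on this read-out lower numbers stand for a weaker effect and higher numbers for a stronger effect at the one concentration tested), compound 1 gives 108% and compound 2 gives 100%. Compound 2 stands alongside compound 1 within the scatter, the step of a number 8 percentage points lower from compound 1 to compound 2 (within the scatter) being the only one measured. Compound 3 `Oc1cc(C(F)(F)F)ccc1-c1nc(-c2ccccc2O)n(-c2ccc(I)cc2)n1` differs from compound 2 by iodo in place of bromo on an aromatic carbon. Within the data shown here, the one measured step, a number 8 percentage points lower from compound 1 to compound 2 (within the scatter), exchanged groups on the same aromatic carbon without moving the read-out beyond the scatter; nothing measured speaks to iodo itself. The expected step is therefore none beyond the scatter, no change at the digits printed from compound 2 to compound 3 (within the scatter). Compound 3 is expected to give 100%, between 85% and 115%.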

Compound 3, a percentage reported as activity, at one concentration (the size of the read-out at that concentration, not a potency): 105%
The estimate for compound 3 lay 5 percentage points below the measured number; the measured number falls inside the stated range.
By their numbers in this assay, from the lowest: compounds 2, 3 and 1 (each within the scatter of the next).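

In this assay, the change from 4-bromophenyl to 4-iodophenyl gives a number 5 percentage points higher from compound 2 to compound 3 (within the scatter), and iodo in place of isopropyl gives a number 3 percentage points lower from compound 1 to compound 3 (within the scatter). On this aromatic carbon, isopropyl, bromo and iodo therefore cannot be told apart in this read-out, as compound 1, compound 2 and compound 3 all lie within the scatter of one another. No measurement is available that would explain this result. Still open, going by these compounds, is whether an amine, a carboxylic acid or a longer alkyl chain at this place would move the read-out beyond the scatter.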